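Compound 4: A New Ring on the Shared Core

This account rests on a few compounds, and the source may have more. Where it says the series, first, only, none or still open, it means among the compounds named here.

Measured in a functional assay with Oryctolagus cuniculus as the target; a higher number here means a weaker inhibitor, a lower number a stronger inhibitor:
- Compound 1 `COc1ccc(-c2nc(N=C(N)N)sc2-c2ccc(OC)cc2)cc1`: 31000 nM
- Compound 2 `COc1ccc(-c2nc(CNC(=O)CSC)sc2-c2ccc(OC)cc2)cc1`: < 100 nM (a limit)
- Compound 3 `COc1ccc(-c2nc(C(=O)N3CCCCC3)sc2-c2ccc(OC)cc2)cc1`: > 1000 nM (a limit)

Compound 3 has only a limit, > 1000 nM, so its starting point is not an exact number.

Compound 4 `COc1ccc(-c2nc(C3=NNC(=O)CC3)sc2-c2ccc(OC)cc2)cc1` keeps the shared core and replaces the (piperidin-1-yl)carbonyl of compound 3: a group of 7 heavy atoms (4 carbon, 2 nitrogen, 1 oxygen; one six-membered non-aromatic ring with 2 hetero atoms) in place of a group of 8 heavy atoms (6 carbon, 1 nitrogen, 1 oxygen; one six-membered non-aromatic ring with 1 hetero atom), on an aromatic carbon.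

Three measured steps involve changes at this same place. The first is an at least 310-fold lower number from compound 1 to compound 2 (2.49 log units; beyond the scatter), and the second is an at least 10-fold higher number from compound 2 to compound 3 (1.00 log units; beyond the scatter). The third is a step that the limit leaves unreadable from compound 1 to compound 3. None of them brings in the new ring, so they show only that this place can strongly shift the number. The step of an at least 10-fold higher number from compound 2 to compound 3 (1.00 log units; beyond the scatter) also shows that this place can carry a lower number than compound 3 does, so a move in that direction is tentatively expected.

In this assay, the estimated change is an at least 1.6-fold lower number from compound 3 to compound 4 (0.22 log units; that floor lies within the scatter). Compound 4 is expected at 600 nM, within an estimated range of 60 nM to 6000 nM.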

Compound 4, half-maximal inhibitory concentration: > 1000 nM
Compound 4: a limit, no number; the forecaster's own chance of this, stated with the estimate: 30%; at least 1.6-fold (0.22 log units) between middle value and limit.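

In this assay compound 4 has only a limit, > 1000 nM. Within the data shown here, the one step that can be read is an at least 10-fold higher number from compound 2 to compound 4 (1.00 log units; beyond the scatter), so the new six-membered ring with two hetero atoms, like the ring of compound 3, does not bring the number down to the level of the open chain in compound 2. Lacking a ring here is not enough on its own, though: compound 1, which also has no ring at this place, gives 31000 nM.

The steps from compound 3 to compound 4 and from compound 1 to compound 4 cannot be read, so the order of these compounds stays open: the limit of > 1000 nM in this assay, at which 2 of the 4 values shown sit. Also open is whether an amine or a longer chain at this place would give a number as low as that of compound 2.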